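Small ring change, cytotoxicity expected to hold

The source may hold more compounds than are shown below. What is called first, only, known or untested is meant among the compounds shown, and "the series" means these compounds.

Compound 1 `Cc1cccc(C)c1Oc1cc(Nc2ccc(C#N)cc2)[nH]c(=O)c1Cl`: 29000 nM
Compound 2 `Cc1cc(C)cc(Oc2cc(Nc3ccc(C#N)cc3)[nH]c(=O)c2Cl)c1`: 21000 nM

In an ADME assay on MT4 cells (Homo sapiens) for cytotoxicity, read by MTT assay, with a stated time of 5 days (on this read-out higher numbers stand for lower toxicity in this test and lower numbers for higher toxicity in this test), compound 2 gives 21000 nM, which lies within the usual scatter of compound 1 at 29000 nM. The two therefore cannot be told apart on this read-out. The next compound, compound 3 `Cc1cc(C)c(Oc2cc(Nc3ccc(C#N)cc3)[nH]c(=O)c2Cl)c(C)c1`, has 2,4,6-trimethylphenyl in place of 3,5-dimethylphenyl on an oxygen on an aromatic ring. For the measured compounds named here, the only measured step that bears on this is the exchange of 2,6-dimethylphenyl for 3,5-dimethylphenyl at the same place, a 1.4-fold lower number from compound 1 to compound 2 (0.14 log units; within the scatter). Going by the values given here, no measured step shows a swap to 2,4,6-trimethylphenyl, so the evidence is thin. Among the compounds with values here, with only that small step to go on, the expected change in this assay is a 1.1-fold higher number from compound 2 to compound 3 (0.06 log units; within the scatter), with no shift beyond the scatter expected in either direction. Compound 3 is estimated at 24000 nM, with an expected range from 11000 nM to 50000 nM.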

Compound 3, half-maximal cytotoxic concentration: > 329000 nM
Compound 3: only a limit was reported; the forecaster's own chance of this, stated with the estimate: 10%; middle value at least 13-fold (1.13 log units) from the limit.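

In this assay, the aryl group on the oxygen proves able to shift the number well beyond the scatter: 2,4,6-trimethylphenyl in place of 3,5-dimethylphenyl gives an at least 15-fold higher number from compound 2 to compound 3 (1.19 log units; beyond the scatter). A single methyl in place of hydrogen on an aromatic carbon of the 2,6-dimethylphenyl group gives an at least 11-fold higher number from compound 1 to compound 3 (1.05 log units; beyond the scatter), so one added carbon separates a clear cytotoxic reading from a much higher one. The reading for compound 3 is a limit of the assay and not a number: the limit of > 329000 nM in this assay, at which 1 of the 3 values shown sits.

Going by these compounds, how far the true value of compound 3 lies past that limit stays open, and so does the full size of both steps. Also open, on these data alone, is whether a methoxy group or an amine in place of that added methyl would give the same large rise.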